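From Compound 1 to Compound 4: Changing the Tail

The source may report more compounds than this note shows. Statements on the series, on what has been measured and on what is new or still open speak of the compounds shown alone.

Compound 1 `CCOC(=O)C1CCN(C(=O)CN2CN(c3ccccc3)C3(CCN(C(=O)c4ccc(C5CCCCC5)cc4)CC3)C2=O)CC1` is the stronger of the two measured analogues: in an assay on HEK293 cells for displacement of a labelled ligand from NPC1-like intracellular cholesterol transporter 1 (Homo sapiens) (a lower number here means a stronger inhibitor, a higher number a weaker inhibitor), compound 1 gives 900 nM, while compound 2 `CC(C)(C)OC(=O)NC1CCN(C(=O)CN2CN(c3ccccc3)C3(CCN(C(=O)c4ccc(C5CCCCC5)cc4)CC3)C2=O)CC1` gives 4800 nM. Compound 3 `CCc1nn(CC)c(C2CCN(C(=O)CN3CN(c4ccccc4)C4(CCN(C(=O)c5ccc(C6CCCCC6)cc5)CC4)C3=O)CC2)c1C` has no numerical result; in this assay compound 3 gives "not determined" (no result reported). For the measured compounds named here, the single known step, a 5.3-fold higher number from compound 1 to compound 2 (0.73 log units; beyond the scatter), follows from (tert-butoxycarbonyl)amino in place of ethoxycarbonyl on a saturated ring carbon. Compound 4 `NC(=O)C1CCCN(C(=O)CN2CN(c3ccccc3)C3(CCN(C(=O)c4ccc(C5CCCCC5)cc4)CC3)C2=O)C1` again alters the group on that carbonyl carbon: 3-carbamoylpiperidin-1-yl in place of 4-(ethoxycarbonyl)piperidin-1-yl on a carbonyl carbon. Because compound 2 showed a 5.3-fold higher number from compound 1 to compound 2 (0.73 log units; beyond the scatter) after a change at this end, a somewhat weaker result is expected here too, and the step of a 2.8-fold higher number from compound 1 to compound 4 (0.44 log units; beyond the scatter) is the estimate of its size. Compound 4 is thus expected to give 2500 nM in this assay, within a likely range from 900 nM to 7000 nM.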

Compound 4, half-maximal inhibitory concentration: 3100 nM
For compound 4 the middle estimate is 1.2-fold (0.09 log units) below the measured one; the measured number falls inside the stated range.
By their numbers in this assay, from the lowest: compound 1; then compounds 4 and 2 (each within the scatter of the next).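

The step to 3-carbamoylpiperidin-1-yl (a 3.4-fold higher number from compound 1 to compound 4 (0.54 log units; beyond the scatter)) shows that a second replacement of 4-(ethoxycarbonyl)piperidin-1-yl on this carbonyl carbon also gives a weaker inhibitor than compound 1. Compound 4 and compound 2 lie within the scatter of each other, despite their different tails. No measurement shown explains this result.

Compound 4 changes both the ring position and the group, and the compounds shown do not separate these two changes. On these data alone, how 4-carbamoylpiperidin-1-yl, or a carboxylic acid in place of the ethyl ester, would compare remains open.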